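Enlarging the amine end of compound 2

The source may hold more compounds than are shown below. What is called first, only, known or untested is meant among the compounds shown, and "the series" means these compounds.

In an ADME assay on microsomes from liver (Rattus norvegicus) for metabolic stability, read by LC-MS, using NADPH, at 37 degrees C (on this read-out lower numbers stand for a shorter-lived compound and higher numbers for a longer-lived compound), compound 2 (`Cc1ccccc1-c1nc(CN2CCC(C(=O)NCCCN3CCCCC3)CC2)c(C)o1`) gives > 0.5 h, which is a limit and not a number. Compound 1 (`Cc1cc(C)c(-c2nc(CN3CCC(C(=O)NCCCN4C[C@H](C)C[C@H](C)C4)CC3)c(C)o2)c(C)c1`) gives > 0.5 h, also a limit. Both sit at the limit of > 0.5 h in this assay, at which 2 of the 3 values shown sit, so compound 2 has no exact position on the scale. Compound 3 (`Cc1oc(-c2c(Cl)cccc2Cl)nc1CN1CCC(C(=O)NCCCN2C[C@H](C)C[C@H](C)C2)CC1`) gives a true number, 0.0483 h.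

Compound 4 (`Cc1ccccc1-c1nc(CN2CCC(C(=O)NCCCN3CC4CCCC(C4)C3)CC2)c(C)o1`) differs from compound 2 in one place: a group of 9 heavy atoms (8 carbon, 1 nitrogen; one six-membered non-aromatic ring of carbon only, one six-membered non-aromatic ring with 1 hetero atom) in place of a group of 6 heavy atoms (5 carbon, 1 nitrogen; one six-membered non-aromatic ring with 1 hetero atom), on a saturated chain carbon, three bonds along the chain from an amide-type nitrogen. The entering group adds a six-membered non-aromatic ring of carbon only to the six-membered non-aromatic ring with 1 hetero atom.

Within the data shown here, the only measured step, an at least 10-fold lower number from compound 1 to compound 3 (1.01 log units; beyond the scatter), is large, but it falls on an aromatic carbon and not on the saturated chain. It bears on this change only indirectly, showing that a single replacement can move a compound in this series well down the scale in this assay. Among the measured compounds shown here, no measured step covers the group changed here, so the expectation is loose. The expected step is an at least 1.6-fold lower number from compound 2 to compound 4 (0.22 log units; that floor lies within the scatter), a moderate move towards a shorter half-life, and a further limit reading remains possible. For compound 4 the estimated half-life is 0.3 h, with an expected range of 0.08 h to 1 h.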

Compound 4, half-life: 0.123 h
Compound 4: middle estimate off by 2.4-fold (0.39 log units), on the high side; measured number inside the range.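

Notes on the amine end. In this assay, the place on a saturated chain carbon, three bonds along the chain from an amide-type nitrogen, is not neutral: replacing piperidin-1-yl with the larger group that adds a six-membered non-aromatic ring of carbon only gives an at least 4.0-fold lower number from compound 2 to compound 4 (0.60 log units; beyond the scatter), so a change here can move the half-life beyond the scatter. Among these compounds, until now the only measured step, an at least 10-fold lower number from compound 1 to compound 3 (1.01 log units; beyond the scatter), lay on an aromatic carbon, and the new step shows that the amine end also matters in this assay. The new step is only a floor, and its full size cannot be read, because compound 2 stands at a limit: the limit of > 0.5 h in this assay, at which 2 of the 4 values shown sit.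

The compounds shown do not separate the effect of the added ring from that of the added heavy atoms, and they do not tell whether a morpholin-4-yl or a plain dimethylamino group at this place would give a longer or a shorter half-life. Going by these compounds, whether the same replacement would move a compound carrying the 2,6-dichlorophenyl group in the same direction also stays open.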